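Cyano in Place of Bromo on the Phosphate Aryl Ester

The source may report more compounds than this note shows. Statements on the series, on what has been measured and on what is new or still open speak of the compounds shown alone.

Of the compounds shown here, two have been measured in a physicochemical assay for metabolic stability, read by HPLC; on this read-out lower numbers stand for a shorter-lived compound and higher numbers for a longer-lived compound. Compound 1 `O=c1ccn([C@H]2CC[C@@H](COP(=O)(O)Oc3ccccc3)O2)c(=O)[nH]1` gives 25.1 h. Compound 2 `Cc1cn([C@H]2C[C@H](N=[N+]=[N-])[C@@H](COP(=O)(O)Oc3ccc(Br)cc3)O2)c(=O)[nH]c1=O` gives 7.97 h, the lower of the two numbers, with compound 1 standing a step beyond the scatter above it. Compound 3 `Cc1cn([C@H]2C[C@H](N=[N+]=[N-])[C@@H](COP(=O)(O)Oc3ccc(C#N)cc3)O2)c(=O)[nH]c1=O` differs from compound 2 in one place: cyano in place of bromo on an aromatic carbon. Among the measured compounds shown here, no measured pair shows what this change does in this assay, so the expected step is a 1.0-fold higher number from compound 2 to compound 3 (0.00 log units; within the scatter), not beyond the scatter. Compound 3 is accordingly estimated at 8 h, with a range from 3 h to 20 h.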

Compound 3, half-life: 7.08 h
Compound 3: middle estimate off by 1.1-fold (0.05 log units), on the high side; measured number inside the range.
By their numbers in this assay, from the lowest: compounds 3 and 2 (each within the scatter of the next); then compound 1.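

Among the compounds shown here, this pair gives the first reading of a single change on the aryl ester: in this assay the step is a 1.1-fold lower number from compound 2 to compound 3 (0.05 log units; within the scatter) and so stays within the scatter. With the ring and the shared core held constant, cyano and bromo at this place, para to a large group, cannot be told apart on this read-out, even though cyano adds a hydrogen-bond acceptor. Nothing available bears on why the two groups read alike.

As far as these compounds go, whether an amine or a carboxylic acid at this place would also stay within the scatter remains open. So does whether cyano in place of bromo would read the same on another core.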